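Three limits, then a pyridin-3-yl analogue

This account rests on a few compounds, and the source may have more. Where it says the series, first, only, none or still open, it means among the compounds named here.

Compound 1, `Cc1cc(NC(=O)Nc2ccccc2F)c2ccccc2n1`, compound 2, `Cc1cc(NC(=O)Nc2cccc(Cl)c2)c2ccccc2n1`, and compound 3, `Cc1cc(NC(=O)Nc2ccc(F)cc2)c2ccccc2n1`, share one core and differ only in the aryl group on the amide-type nitrogen. In an ADME assay on BJ cells (Homo sapiens) for cytotoxicity, with a stated time of 72 h (on this read-out higher numbers stand for an effect only at larger amounts of compound and lower numbers for an effect already at smaller amounts), compound 1 gives only a limit, > 25000 nM. In this assay compound 2 also gives only a limit, > 25000 nM. In this assay compound 3 stands at a limit as well, > 25000 nM, so there is no number that places compound 3 against its two neighbours, whose values are limits too. Accordingly the steps a step that the two limits leave unreadable from compound 1 to compound 2, a step that the two limits leave unreadable from compound 1 to compound 3 and a step that the two limits leave unreadable from compound 2 to compound 3 have no readable size; all that is shown is the limit of > 25000 nM in this assay, at which 3 of the 3 values shown sit.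

Compound 4, `Cc1cc(NC(=O)Nc2cccnc2)c2ccccc2n1`, is the next member, and its change from compound 3 is pyridin-3-yl in place of 4-fluorophenyl on an amide-type nitrogen. Since none of the measured steps has a readable size, nothing among the shown data suggests that this change should move the read-out beyond the scatter. Compound 4 is therefore expected to show a step that the limit leaves unreadable from compound 3 to compound 4 in this assay. For compound 4 the estimate in this assay is 30000 nM, with a range from 15000 nM to 60000 nM, and most probably the assay will again report only a limit.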

Compound 4, half-maximal effective concentration: > 25000 nM
Compound 4: no number, only a limit (the forecaster's own chance of this, stated with the estimate: 85%); the middle value does not contradict the limit.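

Compound 4 joins compound 1, compound 2 and compound 3 at a limit in this assay, so no step among these four compounds can be read, and all that is shown is this: the limit of > 25000 nM in this assay, at which 4 of the 4 values shown sit.

The compounds shown leave open at what concentration, if any, each would show cytotoxicity, and whether the groups on the amide-type nitrogen differ in that respect.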